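Hydroxy to dimethylamino on the pendant phenyl ring

The source may hold more compounds than are shown below. What is called first, only, known or untested is meant among the compounds shown, and "the series" means these compounds.

Measured so far:
compound 1 `COc1cc(/C=C/C(=O)C2=C(/C=C/c3ccc(O)c(OC)c3)NC(=O)NC2c2ccccc2)ccc1O` gives 26.4% in a functional assay, with a stated time of 20 min, tested at 10 uM; on this read-out lower numbers stand for a weaker effect and higher numbers for a stronger effect at the one concentration tested
compound 2 `COc1cc(/C=C/C(=O)C2=C(/C=C/c3ccc(O)c(OC)c3)NC(=O)NC2c2ccc(O)cc2)ccc1O` gives 75% in this assay

Within the data shown here, compound 2 stands highest of the two numbers on this read-out; the only other compound, compound 1, lies a large distance below it, and the single step, a number 48.6 percentage points higher from compound 1 to compound 2 (beyond the scatter), is beyond the scatter. That step is the whole of what is known about the pendant phenyl ring: hydroxy in place of hydrogen on an aromatic carbon raised the read-out strongly.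

Compound 3 `COc1cc(/C=C/C(=O)C2=C(/C=C/c3ccc(O)c(OC)c3)NC(=O)NC2c2ccc(N(C)C)cc2)ccc1O` is not yet measured. Its change from compound 2 is dimethylamino in place of hydroxy on an aromatic carbon. Among the measured compounds shown here, no measured pair covers this exchange; the one step that bears on it only shows that the hydroxy of compound 2 matters. Since dimethylamino brings no hydrogen-bond donor, the gain seen from compound 1 to compound 2 may not carry over in full, so a step downward from compound 2 is expected, though with wide uncertainty. For compound 3 the expected value is 50%, within 22% to 78%. The estimated step is therefore a number 25 percentage points lower from compound 2 to compound 3 (beyond the scatter).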

Compound 3, a percentage reported as activity, at one concentration (the size of the read-out at that concentration, not a potency): 37.6%
Compound 3: the middle estimate sits 12.4 percentage points above what was measured; measured number inside the range.
By their numbers in this assay, from the lowest: compound 1; then compound 3; then compound 2.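

Working notes on the pendant phenyl ring. In this assay, the read-out at this carbon, para to a large group, depends on which group replaces hydroxy: the change to dimethylamino gives a number 37.4 percentage points lower from compound 2 to compound 3 (beyond the scatter) and so does not keep the level of compound 2. Dimethylamino does not return the read-out to the level of the unsubstituted ring either, since the comparison with hydrogen gives a number 11.2 percentage points higher from compound 1 to compound 3 (beyond the scatter) as a modest step, which places the three compounds in the order hydrogen, dimethylamino, hydroxy at this one position. No measurement on hand explains that order, so the loss of the hydroxy hydrogen-bond donor remains only a difference counted between the two structures.

The compounds shown leave open whether a methoxy group or a primary amine at this carbon would read closer to compound 2 or to compound 3, which would help separate the contribution of the hydroxy hydrogen from that of the added carbons. They also leave open whether the hydroxy keeps its effect on another carbon of the same ring, and how the order would look across a range of concentrations rather than at the single one tested.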